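The source may report more compounds than this note shows. Statements on the series, on what has been measured and on what is new or still open speak of the compounds shown alone.

Measured compounds:
Compound 1 `N#C/C(=C/c1ccc2ccccc2c1)C(=O)c1ccc[nH]1` in a functional assay on SJ-G2 cells (Homo sapiens) for cytotoxicity, read by MTT assay, with a stated time of 72 h (on this read-out lower numbers stand for stronger inhibition of growth and higher numbers for weaker inhibition of growth), gives < 10000 nM. For compound 1 this value is a limit of the assay and not a number.
Compound 2 `Cc1ccc(/C=C(/C#N)C(=O)c2ccc[nH]2)cc1` in this assay gives 20000 nM.

Compound 2 carries the only number shown in this assay. For the measured compounds named here, the other value shown sits at a limit of the assay (the limit of < 10000 nM in this assay, at which 1 of the 2 values shown sits), so no step between measured compounds can be drawn, and there is no measured comparison to lean on.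

Compound 3 `N#C/C(=C/c1ccc(O)cc1)C(=O)c1ccc[nH]1` differs from compound 2 in one place: hydroxy in place of methyl on an aromatic carbon. Going by the values given here, with hydroxy in place of methyl on an aromatic carbon, no measured step tells what to expect, so the expectation rests on compound 2 alone. The step from compound 2 to compound 3 is expected to be a 2.0-fold lower number from compound 2 to compound 3 (0.30 log units; within the scatter), a modest move toward stronger inhibition of growth that may not exceed the usual scatter. Compound 3 is therefore estimated at 10000 nM, with a range from 2500 nM to 40000 nM.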

Compound 3, concentration for 50% growth inhibition: < 10000 nM
Compound 3 was reported as a limit; the forecaster's own chance of this, stated with the estimate: 30%; the middle value sits exactly at the limit.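

In this assay compound 3 gives < 10000 nM, which is a limit of the assay and not a number. For the compounds shown here, for hydroxy in place of methyl on an aromatic carbon, para to a large group, the result is an at least 2.0-fold lower number from compound 2 to compound 3 (0.30 log units; that floor lies within the scatter), the first step that can be read at this position, although it gives only a floor and not a size. How far the step goes past that floor cannot be read because compound 3 sits at the same limit as most of the series: the limit of < 10000 nM in this assay, at which 2 of the 3 values shown sit.

From the compounds shown here alone, it remains open what a methoxy, an amine or a carboxylic acid would do on this same carbon. The compounds shown also leave open whether a number for this position could be obtained in a range that separates such groups from one another.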